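The source may report more compounds than this note shows. Statements on the series, on what has been measured and on what is new or still open speak of the compounds shown alone.

Working notes on the series, read in a functional assay on BaF3 cells (Mus musculus) for inhibition, read by CCK-8 assay, with a stated time of 72 h; a lower number here means a stronger inhibitor of growth, a higher number a weaker inhibitor of growth. Compound 1 (`Cc1ccc(NC(=O)Nc2ccc(Oc3cc(/N=C/N(C)C)ncn3)cc2)cc1C(F)(F)F`) gives 6610 nM, compound 2 (`CCC(=O)Nc1cc(Oc2ccc(NC(=O)Nc3ccc(C)c(C(F)(F)F)c3)cc2)ncn1`) gives 990 nM, and compound 3 (`C=CC(=O)Nc1cc(Oc2ccc(NC(=O)Nc3ccc(C)c(C(F)(F)F)c3)cc2)ncn1`) gives 1940 nM. Compound 3 therefore holds the second highest of the three numbers. Its nearest neighbour is compound 2, with a 2.0-fold higher number from compound 2 to compound 3 (0.29 log units; within the scatter), while compound 1 lies further off, with a 3.4-fold lower number from compound 1 to compound 3 (0.53 log units; beyond the scatter).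

The next compound is compound 4 (`Cc1ccc(NC(=O)Nc2ccc(Oc3cc(NCCN)ncn3)cc2)cc1C(F)(F)F`), which has 2-aminoethyl in place of vinylcarbonyl on a nitrogen on an aromatic ring. For the measured compounds named here, no measured step makes this exact change. The closest evidence is the exchange of the whole group on an aromatic carbon, which gave a 6.7-fold lower number from compound 1 to compound 2 (0.82 log units; beyond the scatter) as well as the modest step to compound 3 noted above. Vinyl in place of ethyl on the carbonyl carbon stayed small, with a 2.0-fold higher number from compound 2 to compound 3 (0.29 log units; within the scatter). Compound 4 loses that carbonyl, and compound 1, which also has none in this group, gives 6610 nM. A small shift towards a higher number is therefore expected, probably not beyond the scatter. The expected step is a 1.5-fold higher number from compound 3 to compound 4 (0.19 log units; within the scatter). The estimate for compound 4 is 3000 nM, with an expected range of 900 nM to 9000 nM.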

Compound 4, concentration for 50% growth inhibition: > 10000 nM
Compound 4: no number, only a limit (the forecaster's own chance of this, stated with the estimate: 10%); middle value at least 3.3-fold (0.52 log units) away from the limit.
By their numbers in this assay, from the lowest: compounds 2 and 3 (each within the scatter of the next); then compound 1. At a limit, above all of these: compound 4.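

In this assay compound 4 gives > 10000 nM, which is a limit of the assay and not a number, and it is the only reading of this kind in the set: the limit of > 10000 nM in this assay, at which 1 of the 4 values shown sits.

For the compounds shown here, this gives the first sign that the group on this nitrogen can matter by more than the scatter: there is an at least 5.1-fold higher number from compound 3 to compound 4 (0.71 log units; beyond the scatter) and also an at least 10-fold higher number from compound 2 to compound 4 (1.00 log units; beyond the scatter), whereas the earlier change from ethyl to vinyl on the carbonyl carbon stayed within the scatter. Among the compounds shown, the two with a carbonyl in this group, compound 2 and compound 3, have the lower numbers, but the comparison with compound 1, which also has no carbonyl here, stays unresolved, with an at least 1.5-fold higher number from compound 1 to compound 4 (0.17 log units; that floor lies within the scatter) as its only reading.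

The change to 2-aminoethyl removes the carbonyl and brings in a terminal amine in one step, so the compounds shown do not separate these two parts of the change. As far as these compounds go, a 2-hydroxyethyl group on this nitrogen, or an aminoacetyl group that keeps the carbonyl together with the amine, would pull them apart, and the true size of the step remains open while compound 4 stands at a limit.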